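Series notes: cytotoxicity step from compound 2 to compound 4

A few compounds are considered here, and "the series" means these few. Any claim that something is new, unique, unknown or untested is made for them only; others in the source may bear on it.

Measured:
compound 1 `COc1ccccc1N1CCN(C(=O)c2nc3cc(Cl)ccc3s2)CC1` — 63.4%
compound 2 `CN1CCN(C(=O)c2nc3cc(C(F)(F)F)ccc3s2)CC1` — 12.6%
compound 3 `COc1ccccc1N1CCN(C(=O)c2nc3ccccc3s2)CC1` — 53.4%

In an ADME assay on RAW264.7 cells (Mus musculus) for cytotoxicity, read by MTT assay, with a stated time of 72 h, tested at 50 ug/mL (a lower number here means less inhibition, a higher number more inhibition at the concentration tested (going by the name of the read-out)), compound 2 stands lowest of the three; compound 3 lies nearest, compound 1 furthest, both beyond the scatter. Going by the values given here, the one measured step, a number 10 percentage points lower from compound 1 to compound 3 (within the scatter), concerns a group on the aromatic carbon and lies within the scatter; it does not bear on the change to compound 4 `CC(=O)c1ccc(N2CCN(C(=O)c3nc4cc(C(F)(F)F)ccc4s3)CC2)cc1`, which is 4-acetylphenyl in place of methyl on an amine nitrogen in a ring. Compounds 1 and 3 carry an aryl group on that same ring nitrogen and sit well above compound 2, but they differ from it elsewhere too, so this is only a loose guide. Compound 4 is therefore expected to rise, by about a number 32.4 percentage points higher from compound 2 to compound 4 (beyond the scatter), with wide uncertainty. The estimate for compound 4 is 45%, expected between 20% and 70%.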

Compound 4, a percentage reported as inhibition, at one concentration (the size of the read-out at that concentration, not a potency): 30.6%
Beside the measured number, compound 4's estimate is 14.4 percentage points above it; measured number inside the range.
By their numbers in this assay, from the lowest: compound 2; then compound 4; then compounds 3 and 1 (each within the scatter of the next).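

In this assay, going by these compounds alone, this is the first direct reading at the ring nitrogen with the rest of the structure held constant: a number 18 percentage points higher from compound 2 to compound 4 (beyond the scatter), for 4-acetylphenyl in place of methyl. The earlier aryl-bearing compounds differed from compound 2 elsewhere too, so they could not isolate this change. Nothing measured on hand gives a cause for the step.

Going by these compounds, whether the step follows the aromatic ring or the acetyl group remains open. A plain phenyl, or an amine in place of the acetyl, on this nitrogen would separate the two.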